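The source may hold more compounds than are shown below. What is called first, only, known or untested is meant among the compounds shown, and "the series" means these compounds.

Notes on the series in an assay on a protein complex for inhibition of ubiquitin carboxyl-terminal hydrolase 1/WD repeat-containing protein 48 (Homo sapiens), read by fluorescence; on this read-out lower numbers stand for stronger inhibition and higher numbers for weaker inhibition. For the measured compounds named here, compound 1 `Fc1ccc(CNc2nc(-c3ccccc3C(F)(F)F)nc3ccccc23)cc1` gives 3400 nM and compound 2 `FC(F)(F)c1ccccc1-c1nc(NCc2ccc(-c3ccc(Cl)cc3)cc2)c2ccccc2n1` gives 3600 nM; the one measured step, a 1.1-fold higher number from compound 1 to compound 2 (0.02 log units; within the scatter), lies within the scatter. Compound 3 `O=[N+]([O-])c1ccccc1-c1nc(NCc2ccc(-c3cccnc3)cc2)c2ccccc2n1` gives 7800 nM, the highest number of the three, standing beyond the scatter above both compound 2 and compound 1. Compound 4 `CC(C)c1ccccc1-c1nc(NCc2ccc(-c3cccnc3)cc2)c2ccccc2n1` differs from compound 3 by isopropyl in place of nitro on an aromatic carbon. Going by the values given here, no measured step touches this position or this exchange; the only measured step, from compound 1 to compound 2, concerns the other end of the molecule and offers no guide. The expectation is therefore a change no larger than the scatter, with a modest downward lean, giving an estimated step of a 1.6-fold lower number from compound 3 to compound 4 (0.19 log units; within the scatter). Compound 4 is estimated at 5000 nM, within 1500 nM to 16000 nM.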

Compound 4, half-maximal inhibitory concentration: 180 nM
Compound 4: the middle estimate sits 28-fold (1.44 log units) above what was measured; measured number below the stated range.
By their numbers in this assay, from the lowest: compound 4; then compounds 1 and 2 (each within the scatter of the next); then compound 3.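

In this assay, for the compounds shown here, the change from 2-nitrophenyl to 2-isopropylphenyl gives a 43-fold lower number from compound 3 to compound 4 (1.64 log units; beyond the scatter), so this position responds strongly to the group it carries, while the one earlier step, at the other end of the molecule, stayed within the scatter. A nitro group and an isopropyl group of equal heavy-atom count thus part widely here. No measurement at hand accounts for the size of this step.

Open, as far as these compounds go, is how other groups at this place compare, such as methyl, tert-butyl, methoxy or an amine. Also open, from the compounds shown here alone, is whether isopropyl keeps its effect with a different group at the other end of the molecule.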